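The source may hold more compounds than are shown below. What is called first, only, known or untested is meant among the compounds shown, and "the series" means these compounds.

Three compounds with the same core differ only in the saturated group attached through an oxygen on an aromatic ring. In a functional assay on NUGC-3 cells (Homo sapiens) for antiproliferative activity, read by sulforhodamine B assay (on this read-out higher numbers stand for weaker inhibition of growth and lower numbers for stronger inhibition of growth), compound 1 `CC(C)(C)CCOc1cccc(O)c1C(=O)/C=C/c1ccc(O)cc1` gives 3300 nM and compound 3 `O=C(/C=C/c1ccc(O)cc1)c1c(O)cccc1OCC1CCCC1` gives 2140 nM. These two numbers cannot be ranked, since the gap, a 1.5-fold lower number from compound 1 to compound 3 (0.19 log units; within the scatter), lies within the scatter. Compound 2 `O=C(/C=C/c1ccc(O)cc1)c1c(O)cccc1OCCC1CCCCC1` reads > 30000 nM, which is a limit of the assay and not a number. Compound 3 therefore stands level with compound 1 and well clear of that limit, as an at least 14-fold lower number from compound 2 to compound 3 (1.14 log units; beyond the scatter) shows.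

Compound 4 `CCC(CC)COc1cccc(O)c1C(=O)/C=C/c1ccc(O)cc1` carries one change from compound 3: pentan-3-yl in place of cyclopentyl on a saturated chain carbon bound to an oxygen on an aromatic ring. In words, this is pentan-3-yl in place of cyclopentyl on a saturated chain carbon bound to an oxygen on an aromatic ring, so the ring is gone but the carbon count stays the same. For the measured compounds named here, the nearest precedent is the swap between an open-chain group and cyclopentyl seen in a 1.5-fold lower number from compound 1 to compound 3 (0.19 log units; within the scatter), which stayed within the scatter. The large steps, such as an at least 9.0-fold higher number from compound 1 to compound 2 (0.95 log units; beyond the scatter), all involve the cyclohexyl group of compound 2, which compound 4 lacks, so they bear on it less. They do justify a wider range on the weak side.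

In this assay the expected change is a 1.4-fold higher number from compound 3 to compound 4 (0.15 log units; within the scatter), with no step beyond the scatter anticipated. The estimate for compound 4 is 3000 nM, with an expected range of 1200 nM to 9000 nM.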

Compound 4, concentration for 50% growth inhibition: 1960 nM
Compound 4: the middle estimate sits 1.5-fold (0.18 log units) above what was measured; the range from low to high includes it.
By their numbers in this assay, from the lowest: compounds 4, 3 and 1 (each within the scatter of the next). At a limit, above all of these: compound 2.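

Turning the cyclopentyl ring into the open-chain pentan-3-yl group, with the same carbon count, leaves the read-out in this assay level, a 1.1-fold lower number from compound 3 to compound 4 (0.04 log units; within the scatter), and the comparison with the neopentyl group gives the same picture, a 1.7-fold lower number from compound 1 to compound 4 (0.23 log units; within the scatter), so on a saturated chain carbon bound to an oxygen on an aromatic ring, these compounds show no need for a ring. The gap to the cyclohexylmethyl group is large, an at least 15-fold lower number from compound 2 to compound 4 (1.18 log units; beyond the scatter), which leaves that group as the only one here that stands apart from the others. Compound 2 reads as a limit of the assay and not a number, so this step gives only a minimum size: the limit of > 30000 nM in this assay, at which 1 of the 4 values shown sits.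

Still open, going by these compounds, is whether the gap belongs to the cyclohexyl ring itself or to the greater reach of that group, a question that a cyclopentylethyl group, with a five-membered ring on the longer link, would help to answer. All the groups shown are plain saturated carbon, so an amine, a carboxylic acid or a longer straight chain at this place remains untested among these compounds.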